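This account rests on a few compounds, and the source may have more. Where it says the series, first, only, none or still open, it means among the compounds named here.

Compound 1, `COc1ccc(C2=NN(C3=NC(=O)/C(=C4\C(=O)Nc5ccccc54)S3)C(c3ccc(OC)cc3)C2)cc1`, in a functional assay on cells (Leukemia cell, Homo sapiens) for cytotoxicity, read by sulforhodamine B assay, with a stated time of 48 h (a higher number here means a weaker inhibitor of growth, a lower number a stronger inhibitor of growth), gives 100000 nM. Compound 2, `O=C1N=C(N2N=C(c3ccccc3)CC2c2ccc(Cl)cc2)S/C1=C1/C(=O)Nc2ccccc21`, in this assay gives 370 nM.

Within the data shown here, compound 2 holds the lower of the two numbers so far; the only other value, that of compound 1, lies far above it, and the gap between the two is well beyond the scatter of the measurement. Among the measured compounds shown here, the two compounds differ at two places at once, so no single step between measured compounds is available, and nothing tells how much of the gap belongs to each difference.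

Compound 3, `COc1ccc(C2=NN(C3=NC(=O)/C(=C4\C(=O)Nc5ccccc54)S3)C(c3ccc(Cl)cc3)C2)cc1`, is the next compound to be measured. It is built from compound 2 by one change, (methoxy in place of hydrogen on an aromatic carbon), and carries the other substituent of compound 1 as well, so that it stands between the two measured compounds. Because compound 1 gives 100000 nM while compound 2 gives 370 nM, a shift toward the weaker side is expected when the methoxy group is introduced, but of uncertain size. Compound 3 is estimated at 3000 nM, within 500 nM to 30000 nM, a step of an 8.1-fold higher number from compound 2 to compound 3 (0.91 log units; beyond the scatter).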

Compound 3, concentration for 50% growth inhibition: 86600 nM
For compound 3 the middle estimate is 29-fold (1.46 log units) below the measured one, and the stated range ends below it.
By their numbers in this assay, from the lowest: compound 2; then compounds 3 and 1 (each within the scatter of the next).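

Going from phenyl to 4-methoxyphenyl, on an aromatic carbon para to a large group, gives a 230-fold higher number from compound 2 to compound 3 (2.37 log units; beyond the scatter) in this assay and so shows that this single change is enough to produce a large step beyond the scatter. The other difference, chloro in place of methoxy on an aromatic carbon, gives a 1.2-fold lower number from compound 1 to compound 3 (0.06 log units; within the scatter) within the scatter, so with the 4-methoxyphenyl group in place, nearly all of the gap that compound 1 and compound 2 left undivided falls to the methoxy group of the first step. Nothing shown here gives a reason for this large step.

As far as these compounds go, whether chloro matters more when hydrogen stands in place of that methoxy group stays open, since the exchange of chloro for methoxy can be read only on compounds that carry the 4-methoxyphenyl group. Also open, from the compounds shown here alone, is whether the loss belongs to methoxy alone or extends to other groups at this place, such as hydroxyl, fluoro, an amine, a carboxylic acid or a longer chain like ethoxy.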